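Adding a benzyl group to compound 3

The source may report more compounds than this note shows. Statements on the series, on what has been measured and on what is new or still open speak of the compounds shown alone.

In an ADME assay on microsomes from liver (Homo sapiens) for metabolic stability, read by LC-MS, with a stated time of 30 min, tested at 1 uM (a higher number here means that more of the compound is left, a lower number that less of the compound is left), compound 3 `CCNCc1cc(Cl)cc(Nc2nc3cc(F)c(F)cc3[nH]2)c1O` gives > 99% as a limit and not a number. Compound 3 thus stands at the limit of > 99% in this assay, at which 1 of the 3 values shown sits, and has no exact reading. Compound 4 `CCNCc1cc(Cl)cc(Nc2nc3cc(F)c(F)cc3n2Cc2ccc(C(F)(F)F)cc2)c1O` differs from it by 4-(trifluoromethyl)benzyl in place of hydrogen on an aromatic nitrogen in the form of 4-(trifluoromethyl)benzyl in place of hydrogen on an aromatic nitrogen. That same group is carried by two measured compounds. In this assay compound 1 `CC(C)(C)NCc1cc(Cl)cc(Nc2nc3cc(F)c(F)cc3n2Cc2ccc(C(F)(F)F)cc2)c1O` gives 89% and compound 2 `CCNCc1cc(Cl)cc(Nc2nc3ccccc3n2Cc2ccc(C(F)(F)F)cc2)c1O` gives 94% as values within the usual scatter of each other. On those two values, a small fall near the scatter is expected. The expected change is a number at least 8 percentage points lower from compound 3 to compound 4 (that floor lies within the scatter) in this assay and remains an estimate. Compound 4 is estimated at 91% (range 81% to 99%).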

Compound 4, percent of the compound remaining: > 99%
Compound 4 was reported as a limit; the forecaster's own chance of this, stated with the estimate: 10%; middle value at least 8 percentage points away from the limit.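

In this assay compound 4 gives > 99% as a limit of the assay and not a number, so a compound carrying 4-(trifluoromethyl)benzyl on the aromatic nitrogen can reach this limit. Ethyl in place of tert-butyl on an amine nitrogen gives a number at least 10 percentage points higher from compound 1 to compound 4 (that floor lies within the scatter) as the one readable step. The step from hydrogen to 4-(trifluoromethyl)benzyl cannot be read because compound 3 and compound 4 share one limit: the limit of > 99% in this assay, at which 2 of the 4 values shown sit.

The compounds shown leave open how a carboxylic acid or a longer chain in place of 4-(trifluoromethyl)benzyl on that aromatic nitrogen would read in this assay. They also leave open how an amine nitrogen bearing a propyl chain would compare.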